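Chloromethyl Amide Tried Against an Unreadable Background

This account rests on a few compounds, and the source may have more. Where it says the series, first, only, none or still open, it means among the compounds named here.

Of the compounds shown here, three have been measured, and none of them gave a number. Compound 1 `O=C(Nc1ccc(Cl)cc1)c1cc([N+](=O)[O-])ccc1Cl` stands apart from the other structures. In an ADME assay on Raji cells (Homo sapiens) for inhibition, with a stated time of 72 h (on this read-out higher numbers stand for an effect only at larger amounts of compound and lower numbers for an effect already at smaller amounts), compound 1 gives > 25000 nM, which is a limit of the assay. Compound 2 `C/C=C/C(=O)Nc1cccc(-c2nc3ccccc3s2)c1` carries a prop-1-en-1-yl amide on the shared core, and in this assay compound 2 gives > 25000 nM, again a limit. Compound 3 `O=C(O)/C=C/C(=O)Nc1cccc(-c2nc3ccccc3s2)c1` gives > 25000 nM, also a limit. The step that the two limits leave unreadable from compound 2 to compound 3 therefore cannot be read, and the whole picture rests on (the limit of > 25000 nM in this assay, at which 3 of the 3 values shown sit). Compound 2 thus stands at the limit, with no measured number around it.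

Compound 4 `O=C(CCl)Nc1cccc(-c2nc3ccccc3s2)c1` differs from compound 2 by chloromethyl in place of prop-1-en-1-yl on a carbonyl carbon. Among the compounds with values here, no measured step bears on this change, since the only step between neighbours is unreadable and compound 1 has no partner. The measurements give no ground for expecting a shift beyond the scatter in either direction. Compound 4 is therefore estimated at 25000 nM, with a range from 5000 nM to 100000 nM, which means an expected step of a number no higher from compound 2 to compound 4 (the limit leaves the size open).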

Compound 4, half-maximal effective concentration: 1700 nM
Compound 4: the middle estimate sits 15-fold (1.17 log units) above what was measured, and the stated range ends above it.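

The amide position on the shared core does respond to change: chloromethyl in place of prop-1-en-1-yl on the carbonyl carbon gives an at least 14-fold lower number from compound 2 to compound 4 (1.16 log units; beyond the scatter) in this assay. Chloromethyl in place of 2-carboxyethenyl on that carbon gives an at least 14-fold lower number from compound 3 to compound 4 (1.16 log units; beyond the scatter). Compound 4 is thus the only compound shown with a measured number, and both steps give a minimum rather than a full size, since the other end of each sits at a limit: the limit of > 25000 nM in this assay, at which 3 of the 4 values shown sit.

From the compounds shown here alone, what stays open is whether the chlorine itself matters, which a plain methyl, a bromomethyl or a longer chain ending in chlorine on this carbonyl carbon could show. Going by these compounds, the step from compound 2 to compound 3 cannot be read, so the effect of the carboxy group on the chain also remains unknown.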